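A Bromine-for-Trifluoromethyl Swap on Two Related Cores

The compounds below may be only part of what the source reports. "The series", "measured", "known", "first", "only" and "open" are said of these compounds alone.

Compound 1 `COc1cc(Cl)ccc1C(=O)Nc1cc(Br)ccc1O` and compound 3 `COc1ccc(Cl)cc1C(=S)Nc1ccc(Br)cc1O` share much of their build, but how their two cores differ is not broken down here. In a functional assay on HepG2 cells (Homo sapiens) for cytotoxicity, with a stated time of 24 h (a lower number here means a stronger inhibitor, a higher number a weaker inhibitor), compound 1 gives 5630 nM, and compound 3 gives 7600 nM, a pair of numbers within the usual scatter of each other. Compound 2 `COc1cc(Cl)ccc1C(=O)Nc1cc(C(F)(F)F)ccc1O` arises from compound 1 by one change, (trifluoromethyl in place of bromo on an aromatic carbon), and in this assay compound 2 gives 25400 nM, so that a 4.5-fold higher number from compound 1 to compound 2 (0.65 log units; beyond the scatter).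

Compound 4 `COc1ccc(Cl)cc1C(=S)Nc1ccc(C(F)(F)F)cc1O` has not been measured. Within the data shown here, it arises from compound 3 by trifluoromethyl in place of bromo on an aromatic carbon, the same kind of change as the one from compound 1 to compound 2, though not the same: in compound 2 the new group sits meta to a large group and para to a hydroxy group, whereas in compound 4 it sits meta to a hydroxy group and para to a large group. Because compound 3 starts from 7600 nM, and because the earlier step was a 4.5-fold higher number from compound 1 to compound 2 (0.65 log units; beyond the scatter), a step of about a 3.9-fold higher number from compound 3 to compound 4 (0.60 log units; beyond the scatter) is expected in this assay. For compound 4 the estimate is 30000 nM, expected to fall between 12000 nM and 75000 nM.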

Compound 4, half-maximal inhibitory concentration: 3690 nM
The estimate for compound 4 lay 8.1-fold (0.91 log units) above the measured number; the whole stated range lies above it.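

On the core of compound 3, trifluoromethyl in place of bromo gives, in this assay, a 2.1-fold lower number from compound 3 to compound 4 (0.31 log units; beyond the scatter), so the number moves the opposite way to the earlier step on the core of compound 1. This change therefore does not carry over from one core to the other, in size or in direction, and a step read on one of these cores gives no safe forecast for the other: the same change on two cores in this assay, a 4.5-fold higher number (0.65 log units; beyond the scatter) from compound 1 to compound 2 and a 2.1-fold lower number (0.31 log units; beyond the scatter) from compound 3 to compound 4, 9.3-fold (0.97 log units) apart, beyond the scatter of two such steps

What the two pairs do not show is which difference between the cores lies behind this split, or how a third core would behave. The split rests on just these four compounds.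

From the compounds shown here alone, it remains open how other groups in place of bromo, such as a nitrile or a methyl group, would behave on each of the two cores. Also open, going by these compounds, is which core feature matters, a question that pairs differing in one feature of the core at a time could address.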